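The source may report more compounds than this note shows. Statements on the series, on what has been measured and on what is new or still open speak of the compounds shown alone.

Series notes, propargylamine thioethers, an assay on cells for inhibition of Amine oxidase [flavin-containing] B (Homo sapiens), read by fluorescence and Amplex Red, with stated times of 30 min and 15 min; on this read-out lower numbers stand for stronger inhibition and higher numbers for weaker inhibition.

Compound 1 `C#CCNC1CCc2c(SCc3ccc(F)cc3)cccc21` carries fluoro on the aromatic carbon; in this assay compound 1 gives 240 nM. Compound 2 `C#CCNC1CCc2c(SCc3ccc(Cl)cc3)cccc21` differs by chloro in place of fluoro, and in this assay compound 2 gives 180 nM. Going by the values given here, the step of a 1.3-fold lower number from compound 1 to compound 2 (0.12 log units; within the scatter) is the only measured step so far, and it is within the scatter. On the numbers shown, compound 2 stands with the lowest of two values, its nearest neighbour being compound 1 at a gap that does not separate the two.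

Compound 3 `C#CCNC1CCc2c(SCc3ccc(C(C)(C)C)cc3)cccc21` is the next member, not yet measured in this assay. Its change from compound 2 is tert-butyl in place of chloro on an aromatic carbon. Only the halogen swap from compound 1 to compound 2 bears on this change, and it gave no step beyond the scatter, so the present data give no basis for expecting a large shift in either direction when chloro is replaced by tert-butyl at the same aromatic carbon. The expected step is therefore a 1.2-fold higher number from compound 2 to compound 3 (0.09 log units; within the scatter), essentially none beyond the scatter. Compound 3 is estimated at 220 nM in this assay, with a range of 70 nM to 700 nM.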

Compound 3, half-maximal inhibitory concentration: > 20000 nM
Compound 3: a limit, no number; the forecaster's own chance of this, stated with the estimate: 5%; at least 90-fold (1.95 log units) between middle value and limit.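

For compound 3 the read-out in this assay is a limit and not a number: the limit of > 20000 nM in this assay, at which 1 of the 3 values shown sits. The aromatic carbon para to a large group, which showed no separation for the halogen swap (a 1.3-fold lower number from compound 1 to compound 2 (0.12 log units; within the scatter)), proves far from indifferent to what it carries: tert-butyl in place of chloro gives an at least 110-fold higher number from compound 2 to compound 3 (2.04 log units; beyond the scatter), and tert-butyl in place of fluoro gives an at least 83-fold higher number from compound 1 to compound 3 (1.92 log units; beyond the scatter) on the same carbon. The tolerance seen with the two halogens therefore does not extend to every group here, and it ends somewhere between chloro, with 1 heavy atom, and tert-butyl, with 4 heavy atoms, although these compounds do not give the cause.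

The compounds shown leave open where along that run the loss sets in, a point that a methyl, isopropyl or methoxy group on this carbon would help to fix. Also open is how an amine or a carboxylic acid at the same place would read in this assay, since all three groups shown carry no hydrogen-bond donors, no hydrogen-bond acceptors and no net charge.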